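Working notes: the step from compound 2 to compound 3

The source may hold more compounds than are shown below. What is called first, only, known or untested is meant among the compounds shown, and "the series" means these compounds.

Measured so far in a functional assay on HCT-116 cells (Homo sapiens) for inhibition, read by colorimetric assay, with a stated time of 3 days; a lower number here means a stronger inhibitor, a higher number a weaker inhibitor
- compound 1 `O=C(CCCCCCNC(=O)C(O)(O)C(F)(F)F)Nc1ccc(S(F)(F)(F)(F)F)cc1` gives 9110 nM
- compound 2 `COc1cccc(NC(=O)CCCCCCNC(=O)C(O)(O)C(F)(F)F)c1` gives 6110 nM

On these numbers compound 2 (6110 nM) stands within the scatter of compound 1 (9110 nM), and neither ranks ahead of the other. Compound 3 `O=C(CCCCCCNC(=O)C(O)(O)C(F)(F)F)Nc1ccc(Cl)cc1`, not yet measured, differs from compound 2 in one place, with 4-chlorophenyl in place of 3-methoxyphenyl on an amide-type nitrogen. Within the data shown here, no measured step shows what this exchange does. The two values in hand give no spread beyond the scatter, so no step beyond the scatter is expected in this assay, in either direction. The estimated step of a 1.1-fold higher number from compound 2 to compound 3 (0.06 log units; within the scatter) is expected to stay within the scatter. Compound 3 is estimated at 7000 nM (expected range 3000 nM to 16000 nM).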

Compound 3, half-maximal inhibitory concentration: 4230 nM
Beside the measured number, compound 3's estimate is 1.7-fold (0.22 log units) above it; measured number inside the range.
By their numbers in this assay, from the lowest: compounds 3, 2 and 1 (each within the scatter of the next, the first and the last beyond it).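

In this assay, the exchange of 3-methoxyphenyl for 4-chlorophenyl on the amide-type nitrogen gives a 1.4-fold lower number from compound 2 to compound 3 (0.16 log units; within the scatter), so this position tolerates the change without separating the two aryl groups. Placing one chlorine atom on the aromatic carbon that carries the fluorine-bearing sulfur group in compound 1 gives a 2.2-fold lower number from compound 1 to compound 3 (0.33 log units; beyond the scatter), a modest step and the first in the series beyond the scatter. Nothing in hand explains either step.

The compounds shown leave open what an amine or a carboxylic acid would do in place of the chlorine on the aromatic carbon. As far as these compounds go, all three compounds also share one chain and one trifluoromethyl-bearing end, so the effect of a longer chain on the shared core remains unknown.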